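Swapping the aryl group on the hydrazone carbon: compound 4

A few compounds are considered here, and "the series" means these few. Any claim that something is new, unique, unknown or untested is made for them only; others in the source may bear on it.

Compound 1, `O=C(COc1cccc2ccccc12)N/N=C/c1ccccc1Cl`, gives 4.54 in a physicochemical assay for lipophilicity, measured as octanol-water partition; a lower number here means a more polar compound, a higher number a more lipophilic compound.
Compound 2, `O=C(COc1cccc2ccccc12)N/N=C/C=C/c1ccccc1`, gives 4.43.
Compound 3, `O=C(COc1cccc2ccccc12)N/N=C/c1cccc(Br)c1`, gives 4.81.

Compound 3 has the highest of the three numbers; compound 1 is nearest, a number 0.27 log units higher from compound 1 to compound 3 (within the scatter), and compound 2 furthest, a number 0.38 log units higher from compound 2 to compound 3 (beyond the scatter). Compound 4, `CSc1ccc(/C=N/NC(=O)COc2cccc3ccccc23)cc1`, has not yet been measured. It differs from compound 3 at one place: 4-(methylsulfanyl)phenyl in place of 3-bromophenyl on a carbon with a double bond to nitrogen. Both measured steps that exchange the group on this carbon bear on the change: a number 0.27 log units higher from compound 1 to compound 3 (within the scatter) and a number 0.38 log units higher from compound 2 to compound 3 (beyond the scatter), one within the scatter and one modest. For compound 4 a step of similar or smaller size is expected, a number 0.21 log units lower from compound 3 to compound 4 (within the scatter), most likely within the scatter. The estimate for compound 4 is 4.6, with a range from 4.3 to 4.9.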

Compound 4, partition coefficient: 4.11
Beside the measured number, compound 4's estimate is 0.49 log units above it; the whole stated range lies above it.
By their numbers in this assay, from the lowest: compound 4; then compounds 2, 1 and 3 (each within the scatter of the next, the first and the last beyond it).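

At this position, the carbon with a double bond to nitrogen, this assay shows that every exchange leading to 4-(methylsulfanyl)phenyl passes the scatter: there is a number 0.70 log units lower from compound 3 to compound 4 (beyond the scatter) and a number 0.43 log units lower from compound 1 to compound 4 (beyond the scatter) and also a number 0.32 log units lower from compound 2 to compound 4 (beyond the scatter) in this small series. Compound 4 therefore stands lowest of the four, and the earlier groups alone gave no sign of a number this low. Going by these compounds, how a phenyl group carrying an amine or a carboxylic acid would stand at this carbon remains open, as does the part played by the sulfur. Nothing measured here explains these steps.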